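The compounds below may be only part of what the source reports. "The series", "measured", "known", "first", "only" and "open" are said of these compounds alone.

Measured so far in an ADME assay on blood (Rattus norvegicus, strain Wistar Han) for protein binding, read by LC-MS, using equilibrium dialysis; a lower number here means a smaller unbound share, a higher number a larger unbound share of the compound
- compound 1 `CNC(=O)c1cc(C(=O)N[C@H]2CC[C@H](O)CC2)n([C@@H](C)c2ccccc2)n1` gives 0.51
- compound 2 `CNC(=O)c1cc(C(=O)N[C@H]2[C@@H]3COC[C@@H]32)c([C@@H](C)c2ccccc2)o1` gives 0.34
- compound 3 `CNC(=O)c1cc(C(=O)N[C@H]2CC[C@H](OC)CC2)n([C@@H](C)c2ccccc2)n1` gives 0.41

Compound 2 at 0.34 lies within the scatter of both other compounds, so the three values set no order among them. The open case is compound 4 `CNC(=O)c1cc(C(=O)N[C@H]2CC[C@H](O)CC2)c([C@@H](C)c2ccccc2)o1`, not yet measured, which keeps the core of compound 2 and differs only in the group on the amide-type nitrogen: a group of 7 heavy atoms (6 carbon, 1 oxygen; one six-membered non-aromatic ring of carbon only) in place of a group of 6 heavy atoms (5 carbon, 1 oxygen; one three-membered non-aromatic ring of carbon only, one five-membered non-aromatic ring with 1 hetero atom), on an amide-type nitrogen. The entering 4-hydroxycyclohexyl also stands on compound 1, on a different core.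

Among the compounds with values here, one measured step bears on this change, and only indirectly: a 1.2-fold lower number from compound 1 to compound 3 (0.09 log units; within the scatter), with methyl in place of hydrogen on an oxygen on a saturated carbon. That step lies within the scatter. Within the data shown here, no measured pair exchanges the leaving group for the entering one, and no measured pair compares the two cores alone. Compound 1 at 0.51 carries the entering group, and its value remains within the scatter of compound 2 at 0.34. On that basis no step beyond the scatter is expected, and the estimated change is a 1.1-fold higher number from compound 2 to compound 4 (0.05 log units; within the scatter). For compound 4 the estimated value is 0.38, with an expected range from 0.24 to 0.58.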

Compound 4, unbound fraction: 0.36
Compound 4: middle estimate off by 1.1-fold (0.02 log units), on the high side; low and high end bracket the measured number.
By their numbers in this assay, from the lowest: compounds 2, 4, 3 and 1 (each within the scatter of the next).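

In this assay, the amide-type nitrogen on the core of compound 2 accepts 4-hydroxycyclohexyl, with 1 hydrogen-bond donor, in place of a group with 0 hydrogen-bond donors and 3 defined stereocentres, and the step, a 1.1-fold higher number from compound 2 to compound 4 (0.02 log units; within the scatter), stays within the scatter, so this exchange of two groups with no net charge resolves no difference in unbound share. Within the data shown here, the same 4-hydroxycyclohexyl now stands on two cores, giving the first pair that differs only in the core: compound 1 gives 0.51 and compound 4 gives 0.36. Nothing available accounts for these numbers, and no measurement beyond the unbound fraction bears on them.

Still open, from the compounds shown here alone, is whether an amine or a carboxylic acid in place of the hydroxyl of 4-hydroxycyclohexyl, on the amide-type nitrogen, would give a step beyond the scatter in this assay. Also open, going by these compounds, is whether the methyl ether that separates compound 3 from compound 1 would behave the same way on the core of compound 4.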